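Exposure after oral dosing: from a cyclopropylphenyl to a methylindolyl

This account rests on a few compounds, and the source may have more. Where it says the series, first, only, none or still open, it means among the compounds named here.

Measured compounds:
compound 1 `CN1CCN(CCCS(=O)(=O)c2ccc3nc(NC(=O)NC(=O)c4cc(-n5cccn5)ccc4Cl)sc3c2)CC1`: 1200 nM
compound 2 `CCc1ccc(Cl)c(C(=O)NC(=O)Nc2nc3ccc(S(=O)(=O)CCCN4CCN(C)CC4)cc3s2)c1`: 1500 nM
compound 3 `CN1CCN(CCCS(=O)(=O)c2ccc3nc(NC(=O)NC(=O)c4cc(C5CC5)ccc4Cl)sc3c2)CC1`: 1400 nM

All three share one core and differ only in a single group on an aromatic carbon. In an ADME assay on the whole organism (strain Han-Wistar) for pharmacokinetics, with Rattus norvegicus as the target, read by LC-MS, at a dose of 2 mg/kg by the oral route (on this read-out lower numbers stand for lower exposure and higher numbers for higher exposure at the dose given), they give numbers that cannot be told apart: the step of a 1.3-fold higher number from compound 1 to compound 2 (0.10 log units; within the scatter), the step of a 1.2-fold higher number from compound 1 to compound 3 (0.07 log units; within the scatter) and the step of a 1.1-fold lower number from compound 2 to compound 3 (0.03 log units; within the scatter) all stay within the scatter of repeated measurements. Compound 3 therefore stands among three equivalent results, neither set apart from compound 1 nor from compound 2.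

Compound 4 `CN1CCN(CCCS(=O)(=O)c2ccc3nc(NC(=O)NC(=O)c4cc5c(ccn5C)cc4Cl)sc3c2)CC1` has not yet been measured. It differs from compound 3 in this way: 5-chloro-1-methyl-1H-indol-6-yl in place of 2-chloro-5-cyclopropylphenyl on a carbonyl carbon. The earlier steps shown here changed a smaller group on the same aromatic carbon and left the read-out unchanged; the present change is larger, replacing the whole substituted phenyl by a fused bicyclic group, so the measured steps bear on it only loosely. On the evidence of those steps, no shift beyond the scatter is expected in this assay, and the expected step is a 1.3-fold lower number from compound 3 to compound 4 (0.10 log units; within the scatter). Compound 4 is therefore estimated at 1100 nM, with a likely range from 400 nM to 3000 nM. The range is set wide: the structural change is greater than any measured so far.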

Compound 4, maximal plasma concentration: 300 nM
Compound 4: middle estimate off by 3.7-fold (0.56 log units), on the high side, and the stated range ends above it.
By their numbers in this assay, from the lowest: compound 4; then compounds 1, 3 and 2 (each within the scatter of the next).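

In this assay the three compounds with a substituted phenyl on the carbonyl carbon gave numbers within the scatter of one another, so the first clear change appears only when that whole phenyl gives way to 5-chloro-1-methyl-1H-indol-6-yl, with a 4.7-fold lower number from compound 3 to compound 4 (0.67 log units; beyond the scatter) and a 5.0-fold lower number from compound 2 to compound 4 (0.70 log units; beyond the scatter) and a 4.0-fold lower number from compound 1 to compound 4 (0.60 log units; beyond the scatter) all beyond the scatter. The fall is modest but appears against each of the three phenyl compounds, so this position is not indifferent to every change: swapping the ethyl, cyclopropyl or 1H-pyrazol-1-yl group leaves exposure in place, whereas replacing the whole group lowers it. Nothing available here explains why exposure falls with this replacement.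

The compounds shown leave open whether the lower number follows the fused pair of rings as a whole or a single part of it, such as the methyl on its nitrogen. They also leave open whether the phenyl series would hold its level with an amine or a carboxylic acid in place of cyclopropyl.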